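Swapping the amine substituent: from chlorophenylethyl to cyclopentyl

This account rests on a few compounds, and the source may have more. Where it says the series, first, only, none or still open, it means among the compounds named here.

Compounds measured so far:
- compound 1, `C[C@@H](Nc1c(C(N)=O)cnc2ccc(C#N)cc12)c1ccc(Cl)cc1`, 10 uL/min
- compound 2, `C[C@@H](Nc1c(C(N)=O)cnc2ccc(-c3cccnc3)cc12)c1ccc(Cl)cc1`, 11 uL/min

In an ADME assay on cells (Hepatocyte, Homo sapiens) for metabolic stability, with a stated time of 90 min (on this read-out lower numbers stand for slow clearance and higher numbers for fast clearance), compound 1 gives 10 uL/min and compound 2 gives 11 uL/min. Within the data shown here, the only step seen so far, a 1.1-fold higher number from compound 1 to compound 2 (0.04 log units; within the scatter), concerns a different part of the molecule. Compound 2 has the higher of the two numbers, but the gap to compound 1 falls within the scatter, so the two are indistinguishable.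

Compound 3, `NC(=O)c1cnc2ccc(-c3cccnc3)cc2c1NC1CCCC1`, differs from compound 2 in one place: cyclopentyl in place of 1-(4-chlorophenyl)ethyl on a nitrogen on an aromatic ring. Among the measured compounds shown here, no measured step touches this nitrogen substituent, so there is nothing to anchor an expectation beyond the two compounds themselves, which both sit at the low end of this assay. A step of roughly a 1.1-fold higher number from compound 2 to compound 3 (0.04 log units; within the scatter) is expected, that is, no change beyond the scatter. Compound 3 is therefore estimated at 12 uL/min, within 5 uL/min to 30 uL/min.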

Compound 3, intrinsic clearance in a liver preparation (reported as CLH), per the amount of preparation that the assay uses: 23 uL/min
Compound 3: middle estimate off by 1.9-fold (0.28 log units), on the low side; measured number inside the range.
By their numbers in this assay, from the lowest: compounds 1 and 2 (each within the scatter of the next); then compound 3.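

In this assay, the nitrogen substituent proves to be a place where the read-out can move: cyclopentyl in place of 1-(4-chlorophenyl)ethyl gives a 2.1-fold higher number from compound 2 to compound 3 (0.32 log units; beyond the scatter), a modest step towards faster clearance, but one beyond the scatter, unlike the earlier change from cyano to pyridin-3-yl. This single swap changes several things at once, as the chlorine, the aromatic ring and the defined stereocentre all leave together and a smaller non-aromatic ring enters. Nothing available explains why the number rose.

The compounds shown cannot separate those features, so it stays open which of them matters. A 1-phenylethyl group without the chlorine, or a cyclohexyl group on the same nitrogen, would be needed to begin telling them apart.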